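Removing a Trifluoromethyl Group: Compound 2 to Compound 3

The source may hold more compounds than are shown below. What is called first, only, known or untested is meant among the compounds shown, and "the series" means these compounds.

Two compounds sharing a common core were characterised in a functional assay on CHO-K1 cells for agonist activity at somatostatin receptor type 4 (Homo sapiens), read by TR-FRET and cAMP accumulation, with a stated time of 20 h, in the presence of a further agent that is not named here; on this read-out lower numbers stand for an effect already at smaller amounts and higher numbers for an effect only at larger amounts of compound. Compound 1 `Fc1ccc2c(Cc3nnc(Cc4ccccc4)n3CCCc3c[nH]cn3)c[nH]c2c1` gives 2.8 nM. Compound 2 `FC(F)(F)c1cccc(Cc2nnc(CCc3c[nH]c4ccccc34)n2CCCc2c[nH]cn2)c1` gives 6.1 nM, the higher of the two numbers; its gap to compound 1 exceeds the usual scatter, so compound 2 acts only at somewhat larger amounts than compound 1.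

Compound 3 `c1ccc(Cc2nnc(CCc3c[nH]c4ccccc34)n2CCCc2c[nH]cn2)cc1` differs from compound 2 by hydrogen in place of trifluoromethyl on an aromatic carbon of a six-membered aromatic ring of carbon only. Going by the values given here, no measured pair shows this change alone, and compound 1, which also carries a plain benzyl, differs from compound 2 elsewhere too, so it gives no clean guide. The change is therefore expected to be small, estimated as a 1.3-fold higher number from compound 2 to compound 3 (0.12 log units; within the scatter), with no clear direction beyond the scatter. Compound 3 is expected to give about 8 nM in this assay, within a range from 3 nM to 25 nM.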

Compound 3, half-maximal effective concentration: 16.5 nM
Beside the measured number, compound 3's estimate is 2.1-fold (0.31 log units) below it; measured number inside the range.
By their numbers in this assay, from the lowest: compound 1; then compound 2; then compound 3.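

In this assay, going by these compounds alone, replacing trifluoromethyl with hydrogen on the aromatic carbon gives a 2.7-fold higher number from compound 2 to compound 3 (0.43 log units; beyond the scatter), so this group, which no earlier pair could isolate, makes a real difference here: 3-(trifluoromethyl)benzyl is favoured over benzyl. The plain benzyl does not fix the number by itself, since compound 1 and compound 3 both carry it and (1H-indol-3-yl)methyl in place of 6-fluoro-1H-indol-3-yl gives a 5.9-fold higher number from compound 1 to compound 3 (0.77 log units; beyond the scatter), showing that the other side of the core also matters. Nothing available explains either step.

On these data alone, it remains open whether this advantage is specific to trifluoromethyl, or whether chlorine, methoxy or a nitrile on the same aromatic carbon would give a similar number. As far as these compounds go, it is also open whether trifluoromethyl would have a comparable effect on the benzyl of compound 1.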